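The compounds below may be only part of what the source reports. "The series", "measured", "known", "first", "only" and "open" are said of these compounds alone.

Of the compounds shown here, two sharing one core have so far been tested in a functional assay on SV5A8 cells (Homo sapiens) for cytotoxicity; a lower number here means a stronger inhibitor, a higher number a weaker inhibitor. Compound 1 `COc1ccc(CN2CCC(C(=O)Nc3ccc(CNc4nc(N(C)C)nc5cc(C)ccc45)cc3)CC2)cc1` reaches only the edge of what the measurement can report: in this assay compound 1 gives > 6180 nM, which is a limit and not a number, as the limit of > 6180 nM in this assay, at which 1 of the 2 values shown sits, records. Compound 2 `Cc1ccc2c(NCc3ccc(NC(=O)C4CCN(Cc5ccccc5)CC4)cc3)nc(N(C)CCCN(C)C)nc2c1` ends the same way; in this assay compound 2 gives > 8620 nM, again a limit rather than a number, as the limit of > 8620 nM in this assay, at which 1 of the 2 values shown sits, records. For the measured compounds named here, compound 1 thus stands at a limit, and the only other value shown is a limit too, so no step between measured compounds can be stated. The unmeasured compound 3 `Cc1ccc2c(NCc3ccc(NC(=O)C4CCN(CC5CCNCC5)CC4)cc3)nc(N(C)C)nc2c1` differs from compound 1 in one place: piperidin-4-yl in place of 4-methoxyphenyl on a saturated chain carbon bound to an amine nitrogen in a ring. Going by the values given here, with no measured step to lean on, and with compound 1 itself at a limit, this exchange is expected to bring no shift beyond the usual scatter in this assay in either direction. Compound 3 is therefore expected to sit near the same limit, with an estimated value of 8000 nM, between 3000 nM and 25000 nM. The step that this estimate means, a step that the limit leaves unreadable from compound 1 to compound 3, is expected to be none beyond the scatter.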

Compound 3, half-maximal inhibitory concentration: > 8070 nM
Compound 3: a limit, no number; the forecaster's own chance of this, stated with the estimate: 70%; middle value at least 1.0-fold (0.00 log units) from the limit.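

For the compounds shown here, compound 1 and compound 3 both end at a limit, not a number, in this assay, and no step between these two compounds can be read. The compounds shown leave open whether piperidin-4-yl in place of 4-methoxyphenyl changes the result at all, and what number any of the three compounds would give.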